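From a Limit Value to a 2-Cyanophenyl Estimate

The source may hold more compounds than are shown below. What is called first, only, known or untested is meant among the compounds shown, and "the series" means these compounds.

Compound 1 `O=C1Nc2ccccc2/C1=C/c1ccc(-c2cn(-c3ccccc3F)nn2)cc1` gives 10500 nM in a functional assay on HT-29 cells (Homo sapiens) for inhibition, read by CCK-8 assay, with a stated time of 24 h; on this read-out higher numbers stand for weaker inhibition and lower numbers for stronger inhibition
Compound 2 `O=C1Nc2ccccc2/C1=C/c1ccc(-c2cn(-c3cccc(F)c3)nn2)cc1` gives > 20000 nM as a limit, not a number
Compound 3 `O=C1Nc2ccccc2/C1=C/c1ccc(-c2cn(-c3ccc(Cl)cc3)nn2)cc1` gives 14000 nM in this assay

Compound 2 stands at the limit of > 20000 nM in this assay, at which 1 of the 3 values shown sits, and so has no exact number. Compound 4 `N#Cc1ccccc1-n1cc(-c2ccc(/C=C3\C(=O)Nc4ccccc43)cc2)nn1` carries 2-cyanophenyl in place of 3-fluorophenyl on an aromatic nitrogen and keeps the rest of compound 2 unchanged. Three measured steps swap the group at this same place: an at least 1.9-fold higher number from compound 1 to compound 2 (0.27 log units; that floor lies within the scatter) and a 1.3-fold higher number from compound 1 to compound 3 (0.12 log units; within the scatter) and an at least 1.4-fold lower number from compound 2 to compound 3 (0.15 log units; that floor lies within the scatter) all stay within the scatter. Only a small step toward a lower number, or none beyond the scatter, is therefore expected in this assay for this change. The estimate means an at least 1.6-fold lower number from compound 2 to compound 4 (0.22 log units; that floor lies within the scatter) as the expected step. Compound 4 is estimated at 12000 nM in this assay (range 5000 nM to 20000 nM).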

Compound 4, half-maximal inhibitory concentration: 14400 nM
Compound 4: the middle estimate sits 1.2-fold (0.08 log units) below what was measured; low and high end bracket the measured number.
By their numbers in this assay, from the lowest: compounds 1, 3 and 4 (each within the scatter of the next). At a limit, above all of these: compound 2.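

At this place on the aromatic nitrogen, a ring carrying a nitrile now sits alongside the halogen-carrying rings in this assay: a 1.0-fold higher number from compound 3 to compound 4 (0.01 log units; within the scatter), and a 1.4-fold higher number from compound 1 to compound 4 (0.14 log units; within the scatter). Among these measured pairs, a nitrile in place of a halogen gives no step beyond the scatter. Compound 2 has only a limit, not a number, so an at least 1.3-fold lower number from compound 2 to compound 4 (0.14 log units; that floor lies within the scatter) is a floor and not an exact size: the limit of > 20000 nM in this assay, at which 1 of the 4 values shown sits.

The compounds shown leave open whether an amine or a carboxylic acid on this phenyl ring would give a step beyond the scatter. A longer chain in place of the ring also remains an open case.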